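Will a Third Group Move the Reading?

A few compounds are considered here, and "the series" means these few. Any claim that something is new, unique, unknown or untested is made for them only; others in the source may bear on it.

In a physicochemical assay for solubility, at pH 7.4 (on this read-out lower numbers stand for lower solubility and higher numbers for higher solubility), compound 1 `Cc1cc(NC(=O)Nc2ccccc2C(C)(C)C)c2ccccc2n1` gives 100 nM and compound 2 `COc1ccccc1NC(=O)Nc1cc(C)nc2ccccc12` gives 100 nM, so compound 2 stands level with compound 1. Compound 3 `Cc1cc(NC(=O)Nc2ccccc2C(F)(F)F)c2ccccc2n1` has not been measured, and it differs from compound 2 in one place: trifluoromethyl in place of methoxy on an aromatic carbon. Among the measured compounds shown here, the one measured step that bears on this, methoxy in place of tert-butyl, shows no change at the digits printed from compound 1 to compound 2 (within the scatter). That single step points in no direction, so no shift beyond the scatter is expected in this assay. The expected step is no change at the digits printed from compound 2 to compound 3 (within the scatter). For compound 3 the estimated value is 100 nM, with an expected range of 40 nM to 250 nM.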

Compound 3, solubility: 3800 nM
Compound 3: middle estimate off by 38-fold (1.58 log units), on the low side, outside the stated range (above it).
By their numbers in this assay, from the lowest: compounds 1 and 2 (each within the scatter of the next); then compound 3.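

This place, on an aromatic carbon ortho to a large group, is not indifferent to the group it carries. In this assay, trifluoromethyl in place of methoxy gives a 38-fold higher number from compound 2 to compound 3 (1.58 log units; beyond the scatter), and trifluoromethyl in place of tert-butyl gives a 38-fold higher number from compound 1 to compound 3 (1.58 log units; beyond the scatter), a reach that the level reading of the two earlier groups did not show. Nothing at hand explains this jump.

Only three groups are shown at this place, so it remains open whether the jump is particular to trifluoromethyl. A single fluorine, a nitrile or an amine here could show whether other groups move the reading too.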